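Urea aryl variation on the shared core

The source may hold more compounds than are shown below. What is called first, only, known or untested is meant among the compounds shown, and "the series" means these compounds.

Measured so far:
compound 1, `COc1cc2cc(Oc3ccc(NC(=O)Nc4ccccc4)cc3)c(C)nc2cc1OC`: 48%
compound 2, `COc1cc2cc(Oc3ccc(NC(=O)Nc4ccc(Cl)c(C(F)(F)F)c4)cc3)c(C)nc2cc1OC`: -80.4%

In a functional assay on U-251 cells (Homo sapiens) for inhibition, read by sulforhodamine B assay, with a stated time of 48 h, tested at 10 uM (on this read-out lower numbers stand for a stronger effect and higher numbers for a weaker effect at the one concentration tested), compound 1 gives 48% and compound 2 gives -80.4%. Compound 2 stands lowest of the two numbers measured; its nearest neighbour is compound 1, and the step of a number 128.4 percentage points lower from compound 1 to compound 2 (beyond the scatter) lies beyond the scatter.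

Compound 3, `COc1cc2cc(Oc3ccc(NC(=O)Nc4ccc(Cl)c(Cl)c4)cc3)c(C)nc2cc1OC`, is not yet measured. It differs from compound 2 by chloro in place of trifluoromethyl on an aromatic carbon. Going by the values given here, the only measured step, a number 128.4 percentage points lower from compound 1 to compound 2 (beyond the scatter), exchanges the whole aryl group on the amide-type nitrogen and bears on this change only loosely: it shows that the 4-chloro-3-(trifluoromethyl)phenyl group carries a large lowering, but it does not separate the part of the trifluoromethyl from that of the chloro. With one chloro kept and a second chloro entering, a number near that of compound 2 is expected, with room for a partial move back toward compound 1, so the estimated step is a number 20.4 percentage points higher from compound 2 to compound 3 (beyond the scatter). Compound 3 is expected to give -60%, with a range of -100% to 0%.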

Compound 3, a percentage reported as activity, at one concentration (the size of the read-out at that concentration, not a potency): -32.3%
Beside the measured number, compound 3's estimate is 27.7 percentage points below it; the range from low to high includes it.
By their numbers in this assay, from the lowest: compound 2; then compound 3; then compound 1.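

In this assay the exchange of trifluoromethyl for chloro, ortho to a chloro group, gives a number 48.1 percentage points higher from compound 2 to compound 3 (beyond the scatter) and so is not neutral at this place on the urea aryl ring. The trifluoromethyl group is still not required for a large lowering, since the 3,4-dichlorophenyl group gives a number 80.3 percentage points lower from compound 1 to compound 3 (beyond the scatter) and thereby separates part of the gain over phenyl from trifluoromethyl. No measurement at hand offers a reason for either step.

The compounds shown leave open how much of the lowering the 4-chloro group carries with nothing else on the ring. They also leave open how a methyl, a methoxy or a nitrile would read in place of the trifluoromethyl or the second chloro.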